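Methylating the Phenol: Compound 1 to Compound 4

The source may hold more compounds than are shown below. What is called first, only, known or untested is meant among the compounds shown, and "the series" means these compounds.

Three pyrazole ureas have been examined in a functional assay on SK-OV-3 cells (Homo sapiens) for inhibition, read by sulforhodamine B assay, with a stated time of 48 h, tested at 0.01 uM; on this read-out higher numbers stand for a weaker effect at the one concentration tested and lower numbers for a stronger effect. Compound 1 `O=C(Nc1cccc(-n2cc(-c3ccncc3)c(-c3cc(O)cc(Cl)c3)n2)c1)Nc1ccc(Cl)c(Cl)c1` gives 108% in this assay. Compound 2 `COc1cc(Cl)cc(-c2nn(-c3cccc(NC(=O)Nc4ccc(Cl)c(C(F)(F)F)c4)c3)cc2-c2ccncc2)c1` gives 104%, and compound 3 `COc1cc(Cl)cc(-c2nn(-c3cccc(NC(=O)Nc4cc(C(F)(F)F)cc(C(F)(F)F)c4)c3)cc2-c2ccncc2)c1` gives 100%; both of these numbers differ from that of compound 1 only within the usual scatter of repeated measurements, so the three compounds cannot be told apart on these values. Compound 2 and compound 3 both carry the methoxy rather than the hydroxy group, with other urea aryl substituents, and neither shows anything beyond the scatter against compound 1.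

Compound 4 `COc1cc(Cl)cc(-c2nn(-c3cccc(NC(=O)Nc4ccc(Cl)c(Cl)c4)c3)cc2-c2ccncc2)c1` is the direct counterpart of compound 1 with a single change: methyl in place of hydrogen on an oxygen on an aromatic ring, that is, hydroxy to methoxy on the 3-chloro-5-hydroxyphenyl group, giving 3-chloro-5-methoxyphenyl. Given that compound 2 and compound 3 with this methoxy group sit within the scatter of compound 1, no step beyond the scatter is expected from compound 1 to compound 4 in this assay, and the expected step is a number 4 percentage points lower from compound 1 to compound 4 (within the scatter). Compound 4 is thus estimated to give 104% in this assay, with a range from 92% to 116%.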

Compound 4, a percentage reported as activity, at one concentration (the size of the read-out at that concentration, not a potency): 100%
Estimate against measurement, compound 4: 4 percentage points above; low and high end bracket the measured number.
By their numbers in this assay, from the lowest: compounds 3, 4, 2 and 1 (each within the scatter of the next).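

In this assay, for the compounds shown here, methyl in place of hydrogen on an oxygen on an aromatic ring gives a number 8 percentage points lower from compound 1 to compound 4 (within the scatter) and so, in a direct comparison, hydroxy to methoxy on this ring shows no step that can be told from the scatter. A second place now reads the same way: with the 3-chloro-5-methoxyphenyl group held fixed, chloro in place of trifluoromethyl on an aromatic carbon gives a number 4 percentage points lower from compound 2 to compound 4 (within the scatter) and no step beyond the scatter appears there either. Nothing available explains why either change leaves the read-out within the scatter.

The compounds shown leave open whether either change would separate from the scatter at any other concentration. They also leave open whether a longer chain such as ethoxy, or an amine, in place of the methoxy group would move the read-out beyond the scatter.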